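This account rests on a few compounds, and the source may have more. Where it says the series, first, only, none or still open, it means among the compounds named here.

In a functional assay on cells (Neutrophil, Homo sapiens) for activation, read by luminescence, with a stated time of 60 min (a higher number here means that more compound is needed for the effect, a lower number that less compound is needed), compound 1 `CCc1cc(Cc2cccc(OC)c2)c(=O)n(CC(=O)Nc2ccc(I)cc2)n1` gives 710 nM and compound 2 `COc1cccc(Cc2cc(-c3ccccc3)nn(CC(=O)Nc3ccc(Br)cc3)c2=O)c1` gives 600 nM, two values within the scatter of each other. Compound 3 `Cc1cc(Cc2cccc(Cl)c2)c(=O)n(CC(=O)Nc2ccc(Br)cc2)n1` gives 5000 nM, the highest of the three numbers, and its distance to each of the other two lies beyond the scatter.

Compound 4 `Cc1cc(Cc2cccs2)c(=O)n(CC(=O)Nc2ccc(Br)cc2)n1` stays close to compound 3, with one change thiophen-2-yl in place of 3-chlorophenyl on a saturated chain carbon bound to an aromatic carbon: thiophen-2-yl stands in place of 3-chlorophenyl on a saturated chain carbon bound to an aromatic carbon. For the measured compounds named here, no two measured compounds differ in only one place, so the data contain no direct precedent for this exchange. Compounds 1 and 2 each differ from compound 4 in more than one place, and their lower numbers cannot be assigned to any single part of their structures.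

Going by the values given here, the expectation therefore rests mainly on compound 3 at 5000 nM, the only measured compound that differs from compound 4 in a single place. A slightly lower number is expected, but no change beyond the scatter, and the estimated step is a 1.3-fold lower number from compound 3 to compound 4 (0.10 log units; within the scatter). For compound 4 the expected value is 4000 nM, with an estimated range of 1000 nM to 15000 nM.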

Compound 4, half-maximal effective concentration: 3900 nM
Beside the measured number, compound 4's estimate is 1.0-fold (0.01 log units) above it, and the stated range covers the measured number.
By their numbers in this assay, from the lowest: compounds 2 and 1 (each within the scatter of the next); then compounds 4 and 3 (each within the scatter of the next).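

In this assay, for the compounds shown here, the exchange of 3-chlorophenyl for thiophen-2-yl on a saturated chain carbon bound to an aromatic carbon gives a 1.3-fold lower number from compound 3 to compound 4 (0.11 log units; within the scatter) and provides the first reading between two compounds that differ in one place. At this position, a six-membered aromatic ring of carbon only and a five-membered aromatic ring with 1 hetero atom therefore give values within the scatter of each other, even though the entering group has fewer heavy atoms, has sulfur in place of the chlorine and has a hydrogen-bond acceptor that the leaving group lacks. No measurement shown here explains why the two groups read alike.

The single exchange changes the ring and removes the chlorine together, so the compounds shown do not separate these two changes, and they leave open whether an amine, a carboxylic acid or a longer chain at this position would also stay within the scatter. They also leave open whether thiophen-2-yl would give a similar reading on the core of compound 1 or compound 2.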